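Adding a 4-methylphenyl Group to Two Related Anilines

The compounds below may be only part of what the source reports. "The series", "measured", "known", "first", "only" and "open" are said of these compounds alone.

Three related compounds have been tested in an ADME assay on PBMC cells (Homo sapiens) for cytotoxicity, read by MTT assay, with a stated time of 72 h, in the presence of a further agent that is not named here; a lower number here means a stronger inhibitor, a higher number a weaker inhibitor. Compound 1 `COc1ccc(Nc2ccc3ccccc3n2)cc1` gives 70000 nM. Compound 3 `COc1ccc(Nc2ccccn2)cc1`, built on a smaller core, gives 42000 nM in this assay; how the two cores differ is not broken down here. Compound 2 `COc1ccc(Nc2cc(-c3ccc(C)cc3)ccn2)cc1` gives 34000 nM in this assay. From compound 3 to compound 2 the change is 4-methylphenyl in place of hydrogen on an aromatic carbon, and it brought a 1.2-fold lower number from compound 3 to compound 2 (0.09 log units; within the scatter).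

Compound 4 `COc1ccc(Nc2nc3ccccc3cc2-c2ccc(C)cc2)cc1` has not yet been measured. It differs from compound 1 by 4-methylphenyl in place of hydrogen on an aromatic carbon. Among the measured compounds shown here, this is the same kind of change as the one from compound 3 to compound 2, but not the same: there the new group sat meta to a group of 9 heavy atoms and opposite the ring nitrogen, while here it sits ortho to a group of 9 heavy atoms, two atoms from the ring nitrogen, on a ring that is part of a fused system of two rings. For the measured compounds named here, the only guide is the earlier step, which stayed within the scatter at a 1.2-fold lower number from compound 3 to compound 2 (0.09 log units; within the scatter). Compound 4 is therefore expected to lie close to its parent, with an estimated step of a 1.3-fold lower number from compound 1 to compound 4 (0.10 log units; within the scatter). The estimate for compound 4 in this assay is 55000 nM, between 25000 nM and 110000 nM.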

Compound 4, half-maximal inhibitory concentration: 118000 nM
Estimate against measurement, compound 4: 2.1-fold (0.33 log units) below, outside the stated range (above it).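

In this assay, the same 4-methylphenyl change made on the second core brings a 1.7-fold higher number from compound 1 to compound 4 (0.23 log units; within the scatter). Set beside the earlier step, the result gives no sign that the two cores respond differently to this change: the same change on two cores in this assay, a 1.2-fold lower number (0.09 log units; within the scatter) from compound 3 to compound 2 and a 1.7-fold higher number (0.23 log units; within the scatter) from compound 1 to compound 4, 2.1-fold (0.32 log units) apart, within the scatter of two such steps. This shows that on both cores the step stayed within the usual scatter of repeated measurements, but it does not show that the change acts identically on the two cores, as two such small steps could hide a modest real difference and the new group also sits at a different place on each core.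

The compounds shown leave open whether another group at the same place, such as an amine or a carboxylic acid, would move the number beyond the scatter. They also leave open whether 4-methylphenyl would give a similar result at other places on either core, or on a third core.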